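The compounds below may be only part of what the source reports. "The series", "measured", "known", "first", "only" and "open" are said of these compounds alone.

Of the compounds shown here, three sharing one core have been tested in an ADME assay on L02 cells (Homo sapiens) for cytotoxicity, read by MTT assay, with a stated time of 48 h; a lower number here means a stronger inhibitor, a higher number a weaker inhibitor. Compound 1 `CC[C@@H](C)[C@H](NC(=O)c1ccc(C(CC)(CC)c2ccc(OCC(=O)C(C)(C)C)c(C)c2)n1CC)C(=O)O` gives 1500 nM. Compound 2 `CCn1c(C(=O)N(C)CC(=O)O)ccc1C(CC)(CC)c1ccc(OCC(=O)C(C)(C)C)c(C)c1` gives 8700 nM. Compound 3 `CC[C@@H](C)[C@H](NC(=O)c1ccc(C(CC)(CC)c2ccc(OCC(O)C(C)(C)C)c(C)c2)n1CC)C(=O)O` gives 1400 nM. Compound 4 `CCn1c(C(=O)N(C)CC(=O)O)ccc1C(CC)(CC)c1ccc(OCC(O)C(C)(C)C)c(C)c1` has not yet been measured.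

Compound 2 differs from compound 1 by one change: (carboxymethyl)(methyl)amino in place of (1-carboxy-2-methylbutyl)amino on a carbonyl carbon. That change gave a 5.8-fold higher number from compound 1 to compound 2 (0.76 log units; beyond the scatter), so the cells tolerated compound 2 more than compound 1. Compound 3 differs from compound 1 only in its core: 1-hydroxy-2,2-dimethylpropyl in place of (tert-butyl)carbonyl on a saturated chain carbon bound to an oxygen on an aromatic ring. That change gave a 1.1-fold lower number from compound 1 to compound 3 (0.03 log units; within the scatter), so the two cores behave alike here. Compound 4 differs from compound 3 by the same change seen between compound 1 and compound 2: (carboxymethyl)(methyl)amino in place of (1-carboxy-2-methylbutyl)amino on a carbonyl carbon. The place is the same in both pairs, a carbonyl carbon whose other neighbour is an aromatic carbon, so this is the same change made on a second core.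

Because the core swap a 1.1-fold lower number from compound 1 to compound 3 (0.03 log units; within the scatter) left the number where it was, the change from compound 3 to compound 4 is expected to act as it did from compound 1 to compound 2, and the step is estimated as a 5.7-fold higher number from compound 3 to compound 4 (0.76 log units; beyond the scatter). On that footing compound 4 is expected to give about 8000 nM in this assay, with a likely span from 4000 nM to 16000 nM. This rests on a single measured example of the change, so the expectation is loose.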

Compound 4, half-maximal inhibitory concentration: 32600 nM
Compound 4: the middle estimate sits 4.1-fold (0.61 log units) below what was measured; measured number outside the range, above it.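

In this assay, putting (carboxymethyl)(methyl)amino in place of (1-carboxy-2-methylbutyl)amino raises the number on both cores, but the size of the step does not carry over, as a 23-fold higher number from compound 3 to compound 4 (1.37 log units; beyond the scatter) stands against the earlier step: the same change on two cores in this assay, a 5.8-fold higher number (0.76 log units; beyond the scatter) from compound 1 to compound 2 and a 23-fold higher number (1.37 log units; beyond the scatter) from compound 3 to compound 4, 4.0-fold (0.60 log units) apart, beyond the scatter of two such steps The same square read along its other side agrees, since the swap to 1-hydroxy-2,2-dimethylpropyl, which stays within the scatter on the first pair, gives a 3.7-fold higher number from compound 2 to compound 4 (0.57 log units; beyond the scatter) on the second: the same change on two cores in this assay, a 1.1-fold lower number (0.03 log units; within the scatter) from compound 1 to compound 3 and a 3.7-fold higher number (0.57 log units; beyond the scatter) from compound 2 to compound 4, 4.0-fold (0.60 log units) apart, beyond the scatter of two such steps So in these compounds the direction of the change carried from one core to the other while its size did not, meaning the two changes do not simply add up; however, four compounds form only one such square, and they show neither why this happens nor whether it holds for any other pair of groups.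

It remains open whether the larger step belongs to the methyl of (carboxymethyl)(methyl)amino or to the loss of the branched chain, since the compounds shown change both at once. A pair carrying plain (carboxymethyl)amino on each core would help separate the two, and a pair with a methyl ester in place of the carboxylic acid would test whether the acid matters.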